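Methyl on the phenyl ring of the shared core

This account rests on a few compounds, and the source may have more. Where it says the series, first, only, none or still open, it means among the compounds named here.

Compound 2 `Nc1cccc(-c2cn3nc(-c4ccccc4)sc3n2)c1` holds the only number shown in a functional assay on L1210 cells (Mus musculus) for inhibition, read by cell counting, with a stated time of 2 days; on this read-out lower numbers stand for stronger inhibition and higher numbers for weaker inhibition: compound 2 gives 32000 nM. Compound 1 `Nc1cccc(-c2cn3nc(-c4cccs4)sc3n2)c1` reaches only a limit in this assay, where compound 1 gives > 250000 nM; this is a limit of the assay and not a number (the limit of > 250000 nM in this assay, at which 1 of the 2 values shown sits). Going by the values given here, the single measured step, an at least 7.8-fold lower number from compound 1 to compound 2 (0.89 log units; beyond the scatter), exchanges one aryl group for another on the shared core and leaves the rest untouched.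

Compound 3 `Cc1ccc(-c2nn3cc(-c4cccc(N)c4)nc3s2)cc1` differs from compound 2 by methyl in place of hydrogen on an aromatic carbon. Among the compounds with values here, no measured step touches the phenyl ring itself: the step of an at least 7.8-fold lower number from compound 1 to compound 2 (0.89 log units; beyond the scatter) replaces the whole ring and says nothing about a methyl set on it. A methyl on the six-membered aromatic ring of carbon only, para to a large group, is therefore expected to move the read-out in this assay by no more than the scatter, with no direction favoured. The estimate for compound 3 is 28000 nM, with a range from 9000 nM to 90000 nM, which corresponds to an expected step of a 1.1-fold lower number from compound 2 to compound 3 (0.06 log units; within the scatter).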

Compound 3, half-maximal inhibitory concentration: 4800 nM
The estimate for compound 3 lay 5.8-fold (0.77 log units) above the measured number; the whole stated range lies above it.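

Methyl in place of hydrogen on the phenyl ring gives a 6.7-fold lower number from compound 2 to compound 3 (0.82 log units; beyond the scatter) in this assay, so this place on the ring, para to a large group, responds to a single added carbon and not only to exchange of the whole aryl group, which was all that compound 1 and compound 2 could show. With both of its printed steps beyond the scatter, compound 3 is the strongest of the three in this assay, and 4-methylphenyl in place of thiophen-2-yl gives an at least 52-fold lower number from compound 1 to compound 3 (1.71 log units; beyond the scatter) as the widest step in the series. Compound 1 stands at a limit of the assay and not at a number, so the size of that wider step is a bound only: the limit of > 250000 nM in this assay, at which 1 of the 3 values shown sits.

From the compounds shown here alone, whether the gain belongs to methyl itself or would also appear with ethyl, methoxy, chlorine or a carboxylic acid at the same place stays open, as does the outcome of methyl set elsewhere on the phenyl ring. The amine on the other aryl group stays unchanged across all three compounds, so the effect of an acetamide or a hydroxyl in its place is also unknown.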